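The source may report more compounds than this note shows. Statements on the series, on what has been measured and on what is new or still open speak of the compounds shown alone.

Measured so far in an ADME assay on HFF cells (Homo sapiens) for cytotoxicity, read by MTT assay, with a stated time of 72 h; a higher number here means a weaker inhibitor, a lower number a stronger inhibitor:
- compound 1 `O=C1O[C@H]([C@@H](O)Cn2cc(-c3ccc(Br)cc3)nn2)C(OCc2ccccc2)=C1OCc1ccccc1` gives 5100 nM
- compound 2 `CCCCc1cn(C[C@H](O)[C@H]2OC(=O)C(OCc3ccccc3)=C2OCc2ccccc2)nn1` gives 26300 nM
- compound 3 `COc1ccccc1-c1cn(C[C@H](O)[C@H]2OC(=O)C(OCc3ccccc3)=C2OCc2ccccc2)nn1` gives 50 nM

Compound 3 stands at the lowest number of the three: a 100-fold lower number from compound 1 to compound 3 (2.01 log units; beyond the scatter) and a 530-fold lower number from compound 2 to compound 3 (2.72 log units; beyond the scatter) are both beyond the scatter. Compound 4 `CCCCCCCCCCc1cn(C[C@H](O)[C@H]2OC(=O)C(OCc3ccccc3)=C2OCc2ccccc2)nn1` differs from compound 3 in one place: decyl in place of 2-methoxyphenyl on an aromatic carbon. The step that bears most directly is a 530-fold lower number from compound 2 to compound 3 (2.72 log units; beyond the scatter); read in reverse, putting a group with no ring in place of 2-methoxyphenyl went with a large rise. For the measured compounds named here, no measured pair compares decyl with butyl, so what the longer chain does is unknown. A large rise in this assay is therefore expected for compound 4, a 300-fold higher number from compound 3 to compound 4 (2.48 log units; beyond the scatter), with a wide range. Compound 4 is estimated at 15000 nM, between 2000 nM and 80000 nM.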

Compound 4, half-maximal inhibitory concentration: > 100000 nM
Compound 4: a limit, no number; the forecaster's own chance of this, stated with the estimate: 15%; at least 6.6-fold (0.82 log units) between middle value and limit.
By their numbers in this assay, from the lowest: compound 3; then compound 1; then compound 2. At a limit, above all of these: compound 4.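

In this assay compound 4 gives a limit and not a number: the limit of > 100000 nM in this assay, at which 1 of the 4 values shown sits. At this aromatic carbon, lengthening the chain from butyl to decyl goes with an at least 3.8-fold higher number from compound 2 to compound 4 (0.58 log units; beyond the scatter), the first sign that chain length itself moves the number upward. Decyl also sits far from both aryl groups, with an at least 19-fold higher number from compound 1 to compound 4 (1.29 log units; beyond the scatter) and an at least 2000-fold higher number from compound 3 to compound 4 (3.30 log units; beyond the scatter), so both chains here read higher than both aryl compounds, with no compound against this.

On these data alone, the true size of these steps stays open, as does the course of the change between butyl and decyl. As far as these compounds go, whether an amine or a carboxylic acid at the chain end would keep this trend is also open.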